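Thiophen-2-yl for 2-(4-chlorophenyl)ethenyl in a flat series

The source may report more compounds than this note shows. Statements on the series, on what has been measured and on what is new or still open speak of the compounds shown alone.

Three measured compounds share one core and differ only in the group on one aromatic carbon. Compound 1 `CC(C)(C)Cc1c(-c2ccccn2)sc(N)c1C(=O)c1ccc(Cl)cc1` carries pyridin-2-yl there; in an assay on CHO cells for displacement of a labelled ligand from adenosine receptor A1 (Homo sapiens), read by scintillation counting, tested at 10 uM (on this read-out higher numbers stand for more inhibition at the one concentration tested (going by the name of the read-out) and lower numbers for less inhibition), compound 1 gives 1%. Compound 2 `CC(C)(C)Cc1c(-c2cc(F)ccc2F)sc(N)c1C(=O)c1ccc(Cl)cc1` carries 2,5-difluorophenyl; in this assay compound 2 gives 3%. Compound 3 `CC(C)(C)Cc1c(/C=C/c2ccc(Cl)cc2)sc(N)c1C(=O)c1ccc(Cl)cc1` carries 2-(4-chlorophenyl)ethenyl; in this assay compound 3 gives 1%. Compound 3 thus stands level with compound 1 at the digits shown, the two together the lowest of the three numbers; the step that separates the third number from them is a number 2 percentage points lower from compound 2 to compound 3 (within the scatter). The remaining steps are likewise flat: a number 2 percentage points higher from compound 1 to compound 2 (within the scatter) and no change at the digits printed from compound 1 to compound 3 (within the scatter).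

Compound 4 `CC(C)(C)Cc1c(-c2cccs2)sc(N)c1C(=O)c1ccc(Cl)cc1` has not yet been measured. thiophen-2-yl in place of 2-(4-chlorophenyl)ethenyl on an aromatic carbon The exchanges already made at the same carbon bear on this step: pyridin-2-yl to 2,5-difluorophenyl, pyridin-2-yl to 2-(4-chlorophenyl)ethenyl and 2,5-difluorophenyl to 2-(4-chlorophenyl)ethenyl each left the read-out within the scatter. Nothing in these data gives a reason to expect the thiophen-2-yl group to behave differently, so the expected step is none beyond the scatter, a number 1 percentage points higher from compound 3 to compound 4 (within the scatter). In this assay compound 4 is estimated at 2%, with a range from -5% to 12%.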

Compound 4, a percentage reported as inhibition, at one concentration (the size of the read-out at that concentration, not a potency): 1%
Beside the measured number, compound 4's estimate is 1 percentage points above it; low and high end bracket the measured number.
By their numbers in this assay, from the lowest: compounds 1, 3, 4 and 2 (each within the scatter of the next).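

In this assay, thiophen-2-yl, the only five-membered aromatic ring among the groups shown at this carbon, gives no change at the digits printed from compound 3 to compound 4 (within the scatter), and the exchanges from the other two groups give a number 2 percentage points lower from compound 2 to compound 4 (within the scatter) and no change at the digits printed from compound 1 to compound 4 (within the scatter). The position next to the ring sulfur has now carried groups from 5 to 9 heavy atoms, with and without a double bond outside aromatic rings, and none of the four groups moves the read-out beyond the scatter from any other, so the change to a smaller ring with sulfur adds a further flat step rather than a first difference to interpret. No independent measurement is available to account for this flat result.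

From the compounds shown here alone, whether a basic amine, a carboxylic acid or a longer alkyl chain on this carbon would shift the read-out remains open, as does whether the position stays flat once the neopentyl group or the (4-chlorophenyl)carbonyl group is replaced. With a read-out taken at one concentration and no compound separated from the others, the series also gives no potency and no ranking among these four groups.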